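Exchanging the Chlorophenyl Ketone for a Dimethylphenyl Ketone

The compounds below may be only part of what the source reports. "The series", "measured", "known", "first", "only" and "open" are said of these compounds alone.

Compound 1, `COc1ccc(-c2cc(/C=C/C(=O)c3ccc(Cl)cc3)nc3cc(-c4ccccc4)nn23)cc1OC`, was tested in a functional assay on A549 cells (Homo sapiens) for antiproliferative activity, read by MTT assay, with a stated time of 24 h (a lower number here means a stronger inhibitor, a higher number a weaker inhibitor), where it gives 15400 nM. Its near relative compound 2, `COc1cc(-c2cc(/C=C/C(=O)c3ccc(Cl)cc3)nc3cc(-c4ccccc4)nn23)cc(OC)c1OC`, gives 15500 nM in this assay. For the measured compounds named here, the one measured step, a 1.0-fold higher number from compound 1 to compound 2 (0.00 log units; within the scatter), is a change of methoxy in place of hydrogen on an aromatic carbon, and it leaves the number essentially where it was. Compound 1 thus carries the lowest of the two numbers, yet nothing separates it from compound 2 beyond the scatter.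

Compound 3, `COc1ccc(-c2cc(/C=C/C(=O)c3ccc(C)c(C)c3)nc3cc(-c4ccccc4)nn23)cc1OC`, has not yet been measured. It differs from compound 1 in 3,4-dimethylphenyl in place of 4-chlorophenyl on a carbonyl carbon. Going by the values given here, the only measured step touches a methoxy group on an aromatic carbon and so says nothing about exchanging the group on the carbonyl carbon; no measured step bears on this change. In the absence of guidance, compound 3 is expected to sit near compound 1, so the step of a 1.0-fold lower number from compound 1 to compound 3 (0.01 log units; within the scatter) is expected to be no larger than the scatter. Compound 3 is estimated at 15000 nM, with a range from 6000 nM to 40000 nM.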

Compound 3, half-maximal inhibitory concentration: 9300 nM
Estimate against measurement, compound 3: 1.6-fold (0.21 log units) above, within the range that was stated.
By their numbers in this assay, from the lowest: compounds 3, 1 and 2 (each within the scatter of the next).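

For the compounds shown here, the earlier pair differed only in a methoxy group on an aromatic carbon, so compound 3 is the first to show what happens when the group on the carbonyl carbon is exchanged. In this assay, putting 3,4-dimethylphenyl in place of 4-chlorophenyl gives a 1.7-fold lower number from compound 1 to compound 3 (0.22 log units; within the scatter) and so the two compounds cannot be told apart, which means that this aromatic ring on the carbonyl carbon can carry either substitution without the number leaving the usual scatter. No measurement is available that would explain this result or link it to any property of either group.

Both groups compared here are carbon-only aromatic rings with no hydrogen-bond donors or acceptors, so the compounds shown leave open whether a phenyl ring bearing an amine or a carboxylic acid, or a longer chain in place of the ring, would give a number clearly different from these. They also leave open whether the 3,4-dimethylphenyl group would give a similar result on a core carrying a different methoxy pattern.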